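Dropping the Fluorine: From Compound 2 to Compound 3

This account rests on a few compounds, and the source may have more. Where it says the series, first, only, none or still open, it means among the compounds named here.

Of the compounds shown here, two have so far been measured in a functional assay on COLO 205 cells (Homo sapiens) for inhibition, read by sulforhodamine B assay, with a stated time of 48 h; a lower number here means a stronger inhibitor of growth, a higher number a weaker inhibitor of growth. Compound 1 `N=C(N)c1ccc(-c2ccc(-c3cc(Cl)cc(Cl)c3)s2)cc1` gives 304 nM in this assay, and compound 2 `COc1cc(OC)cc(-c2ccc(-c3ccc(C(=N)N)c(F)c3)s2)c1` gives 208 nM. Compound 2 has the lower of the two numbers, but the nearest value, that of compound 1, lies within the scatter, so the two cannot be ranked against each other.

Compound 3 `COc1cc(OC)cc(-c2ccc(-c3ccc(C(=N)N)cc3)s2)c1` differs from compound 2 in a single place: hydrogen in place of fluoro on an aromatic carbon. Going by the values given here, no step between measured compounds shows what this change does on its own. Among the compounds with values here, the only guide is that compound 2 gives 208 nM while compound 1, built differently at the periphery, gives 304 nM, and these two numbers sit within the scatter of each other; this suggests that modest changes around the shared core do not move the number far. Compound 3 is therefore expected to land close to compound 2, with the step of a 1.3-fold higher number from compound 2 to compound 3 (0.10 log units; within the scatter) expected to stay within the scatter. The estimate for compound 3 in this assay is 260 nM, with a range from 110 nM to 620 nM.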

Compound 3, concentration for 50% growth inhibition: 1330 nM
Estimate against measurement, compound 3: 5.1-fold (0.71 log units) below, and the stated range ends below it.
By their numbers in this assay, from the lowest: compounds 2 and 1 (each within the scatter of the next); then compound 3.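

In this assay, going by these compounds alone, this position is no longer a matter of inference, and the single change can be read directly: hydrogen in place of fluoro gives a 6.4-fold higher number from compound 2 to compound 3 (0.81 log units; beyond the scatter) and so carries the number clearly beyond the scatter. The fluoro sits on an aromatic carbon, ortho to a group of 3 heavy atoms and meta to a large group, and at this place the loss of one heavy atom is enough to separate compound 2, the stronger inhibitor of growth of the pair, from compound 3. Nothing available on these compounds explains why this one atom counts for so much here.

As far as these compounds go, it remains open whether the gain belongs to fluoro itself or whether another group on this carbon, such as a methyl, a methoxy or a nitrile, would serve equally well, or better. From the compounds shown here alone, it is equally open whether a fluoro on this same carbon would bring a similar gain to compound 1, or whether the step holds only with the outer ring that compound 2 and compound 3 share.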